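Diethylcarbamoyl in place of the triazole of compound 3

A few compounds are considered here, and "the series" means these few. Any claim that something is new, unique, unknown or untested is made for them only; others in the source may bear on it.

In an ADME assay on HeLa cells (Homo sapiens) for cytotoxicity, read by MTT assay (a lower number here means a stronger inhibitor, a higher number a weaker inhibitor), compound 1 `COC(=O)CNC(=O)CCC(=O)Oc1ccc(C[C@H]2C(=O)OC[C@@H]2Cc2ccc(OC)c(OC)c2)cc1OC` gives 179000 nM and compound 2 `COc1ccc(C[C@H]2COC(=O)[C@@H]2Cc2ccc(OCC(=O)Nc3ccc(C)cc3)c(OC)c2)cc1OC` gives 228000 nM, with a 1.3-fold higher number from compound 1 to compound 2 (0.11 log units; within the scatter). Compound 3 `COc1ccc(C[C@H]2COC(=O)[C@@H]2Cc2ccc(OCc3cn(-c4ccc(C)cc4)nn3)c(OC)c2)cc1OC` stands at >= 600000 nM, which is a limit of the assay and not a number.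

Compound 4 `CCN(CC)C(=O)COc1ccc(C[C@H]2C(=O)OC[C@@H]2Cc2ccc(OC)c(OC)c2)cc1OC` differs from compound 3 by diethylcarbamoyl in place of 1-(4-methylphenyl)-1H-1,2,3-triazol-4-yl on a saturated chain carbon bound to an oxygen on an aromatic ring: diethylcarbamoyl in place of 1-(4-methylphenyl)-1H-1,2,3-triazol-4-yl. The closest measured change is an at least 2.6-fold higher number from compound 2 to compound 3 (0.42 log units; beyond the scatter), which brought in the triazole, and compound 4 returns to a carbamoyl. The change of chain in the first step stayed within the scatter. A reversal of similar size towards a lower number is therefore expected, an at least 2.4-fold lower number from compound 3 to compound 4 (0.38 log units; beyond the scatter). For compound 4 the expected value is 250000 nM, with an estimated range of 110000 nM to 550000 nM.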

Compound 4, half-maximal inhibitory concentration: 188000 nM
Estimate against measurement, compound 4: 1.3-fold (0.12 log units) above; the range from low to high includes it.
By their numbers in this assay, from the lowest: compounds 1, 4 and 2 (each within the scatter of the next). At a limit, above all of these: compound 3.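

In this assay there is an at least 3.1-fold lower number from compound 3 to compound 4 (0.50 log units; beyond the scatter) on leaving the triazole for diethylcarbamoyl, so the rise seen with the triazole does not carry over to a carbamoyl without a ring. Diethylamino in place of (4-methylphenyl)amino on the carbonyl carbon gives a 1.2-fold lower number from compound 2 to compound 4 (0.08 log units; within the scatter) and the chain of compound 1 gives a 1.1-fold higher number from compound 1 to compound 4 (0.02 log units; within the scatter) as a comparison, so compound 1, compound 2 and compound 4 are not told apart at this position. Compound 3 sits at a limit of the assay and not a number, which leaves the size of its step a bound: the limit of >= 600000 nM in this assay, at which 1 of the 4 values shown sits.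

Still open, on these data alone, is whether the triazole ring or its 4-methylphenyl group separates compound 3 from the carbamoyls. A triazole carrying a methyl group, or a carboxylic acid or an amine on this chain, would test that.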